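Removing the Nitro Group from an Anilino Substituent

The source may report more compounds than this note shows. Statements on the series, on what has been measured and on what is new or still open speak of the compounds shown alone.

Compound 1: `N#Cc1c(Nc2ccccc2Cl)nc(SCc2cn(Cc3ccccc3Cl)nn2)nc1-c1ccccc1`, 1950 nM
Compound 2: `N#Cc1c(Nc2cccc([N+](=O)[O-])c2)nc(SCc2cn(Cc3ccccc3Cl)nn2)nc1-c1ccccc1`, > 64000 nM

Two compounds sharing one core were measured in a functional assay on MCF7 cells (Homo sapiens) for inhibition, read by MTT assay, with a stated time of 72 h; a higher number here means a weaker inhibitor, a lower number a stronger inhibitor. Compound 1, `N#Cc1c(Nc2ccccc2Cl)nc(SCc2cn(Cc3ccccc3Cl)nn2)nc1-c1ccccc1`, gives 1950 nM. For compound 2, `N#Cc1c(Nc2cccc([N+](=O)[O-])c2)nc(SCc2cn(Cc3ccccc3Cl)nn2)nc1-c1ccccc1`, the assay reports only a limit, > 64000 nM. Compound 2 thus stands at the limit of > 64000 nM in this assay, at which 1 of the 2 values shown sits, and its distance from compound 1 is known only as the step of an at least 32-fold higher number from compound 1 to compound 2 (1.51 log units; beyond the scatter).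

Compound 3, `N#Cc1c(Nc2ccccc2)nc(SCc2cn(Cc3ccccc3Cl)nn2)nc1-c1ccccc1`, is not yet measured. It differs from compound 2 by hydrogen in place of nitro on an aromatic carbon. Among the measured compounds shown here, the one measured step that bears on this change is an at least 32-fold higher number from compound 1 to compound 2 (1.51 log units; beyond the scatter), in which 3-nitrophenyl on the ring nitrogen replaced 2-chlorophenyl and the number rose far beyond the scatter. Taking the nitro away from compound 2 reverses the part of that change that introduced nitro, while the chloro of compound 1 stays absent. A large fall in the number in this assay is therefore expected, though not necessarily all the way back to compound 1. The step of an at least 12-fold lower number from compound 2 to compound 3 (1.10 log units; beyond the scatter) is the expected result. For compound 3 a value of 5000 nM is estimated, within a range from 1200 nM to 30000 nM.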

Compound 3, half-maximal inhibitory concentration: > 64000 nM
Compound 3 gave a limit, no number; the forecaster's own chance of this, stated with the estimate: 20%; middle value at least 12-fold (1.10 log units) from the limit.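

In this assay, removing the substituent from the anilino ring does not bring back the activity of compound 1: taking the chloro away gives an at least 32-fold higher number from compound 1 to compound 3 (1.51 log units; beyond the scatter). Among these compounds, then, the chloro of compound 1 is the one substituent that goes with a measured number, and the nitro of compound 2 can no longer be read as the sole reason for the gap between that compound and compound 1, since the ring without nitro also fails to give a number. Compounds 2 and 3 both end at the limit of the assay, so the step between them cannot be read and any effect of taking away the nitro stays hidden: the limit of > 64000 nM in this assay, at which 2 of the 3 values shown sit.

The compounds shown leave open whether the gain belongs to chloro itself or would also appear with another group in its place, such as fluoro, bromo, methyl or methoxy. They also leave open whether a chloro in the place the nitro occupies in compound 2 would give a number in this assay.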